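The compounds below may be only part of what the source reports. "The series", "measured", "known", "first", "only" and "open" are said of these compounds alone.

Measured so far:
compound 1 `CN(C)c1ccc(C(=O)Nc2cccc(NC(=O)COc3ccc4c(c3)NC(=O)CC4)c2)cc1` — > 10000 nM
compound 2 `O=C(COc1ccc2c(=O)ccoc2c1)Nc1cccc(NC(=O)c2ccc(Br)cc2)c1` — 303 nM

In an assay on isolated protein for inhibition of Rho-associated protein kinase 1 (Homo sapiens), read by scintillation counting, radiometric assay and 33P incorporation, with a stated time of 40 min, in the presence of a further agent that is not named here (a higher number here means a weaker inhibitor, a lower number a stronger inhibitor), compound 1 gives only > 10000 nM, which is a limit of the assay and not a number; this is the case noted as the limit of > 10000 nM in this assay, at which 1 of the 2 values shown sits. Among the measured compounds shown here, compound 2 is therefore the only compound with a number in this assay, where compound 2 gives 303 nM. For the measured compounds named here, with only one number among the measured compounds, no ranking among them can be drawn.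

Compound 3 `O=C(COc1ccc2c(=O)ccoc2c1)Nc1cccc(NC(=O)c2cnc(C(F)(F)F)s2)c1` has not been measured. It differs from compound 2 in one place: 2-(trifluoromethyl)-1,3-thiazol-5-yl in place of 4-bromophenyl on a carbonyl carbon. No step between measured compounds covers a change of this kind, so there is nothing among the numbers shown that fixes its size or direction. Replacing one aromatic group on the carbonyl carbon by another aromatic group of similar extent is taken, as a working assumption, to leave potency near that of compound 2, with the step from compound 2 to compound 3 expected to be a 1.3-fold higher number from compound 2 to compound 3 (0.12 log units; within the scatter), that is, none beyond the usual scatter. Compound 3 is therefore estimated at 400 nM in this assay, with a range from 100 nM to 2000 nM.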

Compound 3, half-maximal inhibitory concentration: 160 nM
Estimate against measurement, compound 3: 2.5-fold (0.40 log units) above; measured number inside the range.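

In this assay the place on a carbonyl carbon whose other neighbour is the amide-type nitrogen now carries two measured groups, and putting 2-(trifluoromethyl)-1,3-thiazol-5-yl in place of 4-bromophenyl gives a 1.9-fold lower number from compound 2 to compound 3 (0.28 log units; within the scatter). Among the compounds shown here, this is the first reading of a change at this place: a five-membered aromatic ring with 2 hetero atoms and 2 hydrogen-bond acceptors enters for a six-membered aromatic ring of carbon only with 0 hydrogen-bond acceptors, and the two numbers lie within the scatter of each other. Nothing shown accounts for the size of this step.

The compounds shown leave open how this place reads with something other than an aromatic ring, such as a saturated amine like piperidine or a short alkyl chain, and how it reads with a carboxylic acid on the aromatic ring. Also open, going by these compounds, is what the trifluoromethyl contributes, which the same 1,3-thiazol-5-yl ring carrying a methyl or a hydrogen in its place would settle.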